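The source may hold more compounds than are shown below. What is called first, only, known or untested is meant among the compounds shown, and "the series" means these compounds.

Measured compounds in an assay on HEK293 cells for displacement of a labelled ligand from adenosine receptor A2b (Homo sapiens), read by scintillation counting, with a stated time of 30 min, tested at 10 uM; on this read-out higher numbers stand for more inhibition at the one concentration tested (going by the name of the read-out) and lower numbers for less inhibition:
Compound 1, `N=c1oc2ccc(Br)cc2cc1C(=O)NC1CCCCC1`, gives 10%.
Compound 3, `COc1cccc2cc(C(=O)NCC(O)CO)c(=O)oc12`, gives 25%.
Compound 2, `COC(=O)/C(C#N)=C/c1cccc(OC)c1O`, is reported only as > 70%, which is a limit of the assay and not a number.

Of the two compounds with a number in this assay, compound 1 stands lowest; the nearest is compound 3, whose inhibition lies higher by a gap that exceeds the usual scatter. Compound 2 sits at the limit, (the limit of > 70% in this assay, at which 1 of the 3 values shown sits), and gives no number to compare with.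

The step under consideration leads from compound 1 to compound 4, `N=c1oc2ccc(Br)cc2cc1C(=O)NC1CCCC1`, which is not yet measured. The two structures differ in one place only: cyclopentyl in place of cyclohexyl on an amide-type nitrogen. Going by the values given here, no step between measured compounds of this kind is available, so the size of this change in this assay cannot be read off from a neighbouring pair. Given that only the size of a saturated carbon ring on the amide nitrogen changes, the step from compound 1 to compound 4 is expected to be small, in either direction, and to stay within the scatter of repeated measurements. Compound 4 is therefore estimated to give 12% in this assay, with an expected range from 0% to 35%, the expected step being a number 2 percentage points higher from compound 1 to compound 4 (within the scatter).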

Compound 4, a percentage reported as inhibition, at one concentration (the size of the read-out at that concentration, not a potency): 28%
Estimate against measurement, compound 4: 16 percentage points below, and the stated range covers the measured number.
By their numbers in this assay, from the lowest: compound 1; then compounds 3 and 4 (each within the scatter of the next). At a limit, above all of these: compound 2.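

In this assay, the group on the amide-type nitrogen proves to be a place where a small change registers: cyclopentyl in place of cyclohexyl, with the rest of the structure untouched, gives a number 18 percentage points higher from compound 1 to compound 4 (beyond the scatter). Going by these compounds alone, the earlier compounds offered no pair differing in one place, so this is the first reading of what a single change does, and here the difference is only one ring carbon, a five-membered carbon ring entering where a six-membered one leaves. It remains a single pair that sets no trend, and nothing measured in the material shown accounts for the step.

The compounds shown leave open whether cyclobutyl, cycloheptyl or an open chain such as n-pentyl on the same nitrogen would extend this step or reverse it, and what a cyclopentyl ring carrying an amine or a carboxylic acid would do. They also leave open whether the same exchange of rings would give a step of similar size on a core other than that of compound 1.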